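Adding a Bromine to a Sulfonamide: What to Expect

This account rests on a few compounds, and the source may have more. Where it says the series, first, only, none or still open, it means among the compounds named here.

Measured compounds in a functional assay on A549 cells (Homo sapiens) for antiproliferative activity, read by MTT assay, with a stated time of 72 h; a higher number here means a weaker inhibitor, a lower number a stronger inhibitor:
- compound 1 `COc1ccc(C(=O)N(C)c2ccc3[nH]c(-c4n[nH]c5ccccc45)cc3n2)cc1` gives 14600 nM
- compound 2 `CN(c1ccc2[nH]c(-c3n[nH]c4ccccc34)cc2n1)S(=O)(=O)c1ccccc1` gives 14000 nM

Among the compounds with values here, both numbers are weak, and they sit within the scatter of each other: compound 2 has the lowest of the two numbers, with compound 1 nearest, and the one measured step of a 1.0-fold lower number from compound 1 to compound 2 (0.02 log units; within the scatter) shows that swapping the whole group on the ring nitrogen made no difference worth noting.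

Compound 3 `CN(c1ccc2[nH]c(-c3n[nH]c4ccccc34)cc2n1)S(=O)(=O)c1ccc(Br)cc1` differs from compound 2 in a single place: bromo in place of hydrogen on an aromatic carbon. The change is thus bromo in place of hydrogen on an aromatic carbon of the six-membered carbon-only ring, para to a large group, so that phenylsulfonyl becomes (4-bromophenyl)sulfonyl.

Within the data shown here, no measured step bears directly on this change. Among the measured compounds shown here, the only step known, from compound 1 to compound 2, replaced one large group by another, not a single atom on the outer ring, and it was flat. With nothing pointing either way, the expected step of a 1.2-fold lower number from compound 2 to compound 3 (0.07 log units; within the scatter) is small, without a direction beyond the scatter, and compound 3 is estimated at 12000 nM in this assay, within a range from 4000 nM to 40000 nM.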

Compound 3, half-maximal inhibitory concentration: 19700 nM
The estimate for compound 3 lay 1.6-fold (0.22 log units) below the measured number, within the range that was stated.
By their numbers in this assay, from the lowest: compounds 2, 1 and 3 (each within the scatter of the next).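

In this assay, bromo in place of hydrogen on this six-membered aromatic ring of carbon only, para to a large group, gives a 1.4-fold higher number from compound 2 to compound 3 (0.15 log units; within the scatter). Within the data shown here, this is the first direct reading at this position, and it shows that adding one bromine atom here produces no step that can be told apart from the ordinary spread of repeated measurements. The larger replacement on the nitrogen reads the same way, with a 1.3-fold higher number from compound 1 to compound 3 (0.13 log units; within the scatter), and no measurement available for these compounds offers an explanation for either result.

The compounds shown leave open whether a different group at this position, such as an amine, a carboxylic acid or a longer chain, would give a step beyond the scatter. They also leave open whether a replacement on the shared core, rather than on this outer ring, would move the number by more than the scatter.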